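Carbamoyl added to a dimethyltriazene benzamide

A few compounds are considered here, and "the series" means these few. Any claim that something is new, unique, unknown or untested is made for them only; others in the source may bear on it.

Measured compounds:
compound 1 `CN(C)/N=N/c1ccc(S(N)(=O)=O)cc1C(N)=O`: 3.32
compound 2 `CN(C)/N=N/c1ccc(C(N)=O)cc1`: 3.51

In a functional assay on L1210 cells (Mus musculus) for antiproliferative activity (on this read-out lower numbers stand for lower potency and higher numbers for higher potency (the scale is a negative logarithm)), compound 2 gives 3.51, and the value of compound 1 in this assay, 3.32, lies within the usual scatter of it, so the two cannot be ranked. Compound 3 `CN(C)/N=N/c1ccc(C(N)=O)cc1C(N)=O` has not yet been measured. It differs from compound 2 by carbamoyl in place of hydrogen on an aromatic carbon. Among the compounds with values here, no step between measured compounds is known here. Since compound 1, which carries a group of 5 heavy atoms at the same place, gives 3.32, the estimated step of a number 0.11 log units lower from compound 2 to compound 3 (within the scatter) is expected to be none beyond the scatter. Compound 3 is expected to give 3.4, in the range 3 to 3.9.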

Compound 3, logarithm of the reciprocal of the active concentration, log(1/C): 3.27
Compound 3: the middle estimate sits 0.13 log units above what was measured; low and high end bracket the measured number.
By their numbers in this assay, from the lowest: compounds 3, 1 and 2 (each within the scatter of the next).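

In this assay, carbamoyl in place of hydrogen on this aromatic carbon gives a number 0.24 log units lower from compound 2 to compound 3 (within the scatter), so the read-out does not separate the substituted compound from the unsubstituted one. Carbamoyl in place of sulfamoyl at the same place gives a number 0.05 log units lower from compound 1 to compound 3 (within the scatter), so these two groups cannot be told apart here either. No separate measurement bears on the reason for these results.

Going by these compounds, whether an amine, a carboxylic acid or a longer chain on this aromatic carbon would give a step beyond the scatter remains open.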